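The source may report more compounds than this note shows. Statements on the series, on what has been measured and on what is new or still open speak of the compounds shown alone.

Of the compounds shown here, three built on one shared core have been tested in an assay on isolated protein for inhibition of thyroid hormone receptor beta (Homo sapiens), read by fluorescence polarization; a lower number here means a stronger inhibitor, a higher number a weaker inhibitor. Compound 1 `CS(=O)(=O)c1ccc(C(=O)NCC(=O)N(Cc2ccccc2)Cc2ccccc2)cc1[N+](=O)[O-]` gives 3600 nM in this assay, and it is the only one of the three that returns a number. Compound 2 `CN(Cc1cccc(F)c1)C(=O)CN(C)C(=O)c1ccc(S(C)(=O)=O)c([N+](=O)[O-])c1` gives > 60000 nM, which is a limit of the assay rather than a number. Compound 3 `CN(CC(=O)N(Cc1ccccc1)Cc1ccccc1)C(=O)c1ccc(S(C)(=O)=O)c([N+](=O)[O-])c1` gives > 60000 nM, again a limit. Going by the values given here, the one step between compounds differing in a single place is an at least 16-fold higher number from compound 1 to compound 3 (1.22 log units; beyond the scatter); that change sits on an amide-type nitrogen, not on the chain carbon altered next.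

Compound 4 `CN(Cc1ccccc1)C(=O)CNC(=O)c1ccc(S(C)(=O)=O)c([N+](=O)[O-])c1` differs from compound 1 by hydrogen in place of phenyl on a saturated chain carbon bound to an amide-type nitrogen. Among the compounds with values here, no measured step touches this position, so none bears on it directly. Compound 2 carries methyl rather than benzyl at a comparable position but differs from compound 1 in more than one place, so its limit cannot be assigned to either change. The estimate therefore leans on compound 1 alone, and the expected step is a 4.2-fold higher number from compound 1 to compound 4 (0.62 log units; beyond the scatter), in the weakening direction but uncertain. Compound 4 is expected to give 15000 nM, within 4000 nM to 60000 nM.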

Compound 4, half-maximal inhibitory concentration: 39000 nM
The estimate for compound 4 lay 2.6-fold (0.41 log units) below the measured number; the range from low to high includes it.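

Cutting one benzyl of compound 1 back to methyl gives an 11-fold higher number from compound 1 to compound 4 (1.03 log units; beyond the scatter) in this assay, the first measured effect at this position. The second benzyl therefore matters for the strength of compound 1, since this is a large step beyond the scatter. Yet the loss is not complete. Compound 4 still returns a number, 39000 nM, rather than a limit of the assay.

Going by these compounds, only benzyl and methyl are compared here, so it stays open whether a longer chain such as phenylethyl, or a chain carrying an amine or a carboxylic acid, would regain or lose strength at this place. Compound 2 and compound 3 each stop at a limit of the assay rather than a number, so how weak they really are stays unknown: the limit of > 60000 nM in this assay, at which 2 of the 4 values shown sit.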